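Aryl ketone variation on the pyrazolyl enone series

The source may hold more compounds than are shown below. What is called first, only, known or untested is meant among the compounds shown, and "the series" means these compounds.

Three members of the series have numbers. Compound 1 `COc1ccc(C(=O)/C=C/c2cn(-c3ccccc3)nc2-c2ccsc2)cc1OC` gives 2900 nM in a functional assay on Huh-7 cells (Homo sapiens) for inhibition, read by sulforhodamine B assay, with a stated time of 72 h; on this read-out higher numbers stand for weaker inhibition and lower numbers for stronger inhibition. Compound 2 `O=C(/C=C/c1cn(-c2ccccc2)nc1-c1cccnc1)c1ccsc1` gives 1700 nM. Compound 3 `O=C(/C=C/c1cn(-c2ccccc2)nc1-c1cccnc1)c1ccccn1` gives 6400 nM, the highest of the three, with compound 1 the nearest and compound 2 the furthest. For the measured compounds named here, the one single-point step that has been measured is the exchange on the carbonyl carbon: a 3.8-fold higher number from compound 2 to compound 3 (0.58 log units; beyond the scatter).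

Compound 4 `O=C(/C=C/c1cn(-c2ccccc2)nc1-c1cccnc1)c1cc[nH]c1` differs from compound 3 at the same place: 1H-pyrrol-3-yl in place of pyridin-2-yl on a carbonyl carbon. Going by the values given here, the only step that bears on this change is the one from compound 2 to compound 3, where a five-membered ring at the carbonyl carbon gave the lower number and the six-membered ring the higher. Because a 3.8-fold higher number from compound 2 to compound 3 (0.58 log units; beyond the scatter) ran in that direction, a return to a five-membered ring is expected to move the number back down, though compound 2 carries a sulfur ring and compound 4 a nitrogen ring with a hydrogen-bond donor, so the size is uncertain. The step of a 2.1-fold lower number from compound 3 to compound 4 (0.33 log units; beyond the scatter) is the expected change. Compound 4 is estimated at 3000 nM, within 1200 nM to 8000 nM.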

Compound 4, half-maximal inhibitory concentration: 3300 nM
The estimate for compound 4 lay 1.1-fold (0.04 log units) below the measured number; the measured number falls inside the stated range.
By their numbers in this assay, from the lowest: compounds 2, 1, 4 and 3 (each within the scatter of the next, the first and the last beyond it).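

In this assay, a 1.9-fold lower number from compound 3 to compound 4 (0.29 log units; within the scatter) and a 1.9-fold higher number from compound 2 to compound 4 (0.29 log units; within the scatter) both lie within the scatter, so on this carbonyl carbon 1H-pyrrol-3-yl cannot be told apart from either pyridin-2-yl or thiophen-3-yl, even though those two groups are separated by a 3.8-fold higher number from compound 2 to compound 3 (0.58 log units; beyond the scatter). Ring size therefore does not sort these three groups cleanly, and the entry of a hydrogen-bond donor in place of a hydrogen-bond acceptor gives no step beyond the scatter. No available evidence accounts for these steps.

Compound 1 differs from the others in more than one place, so its steps cannot be read. As far as these compounds go, it remains open whether a piperidin-4-yl ring, a carboxylic acid or a longer alkyl chain on the carbonyl carbon would stay in this range.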